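This account rests on a few compounds, and the source may have more. Where it says the series, first, only, none or still open, it means among the compounds named here.

Compound 1 `O=C(CCCCc1ccccc1)CC(=O)N[C@H]1CCOC1=O`, compound 2 `O=C(CCCc1ccccc1)CC(=O)N[C@H]1CCOC1=O` and compound 3 `O=C(CCCCCCCCCc1ccccc1)CC(=O)N[C@H]1CCOC1=O` share the amide-linked lactone and differ in the chain carrying the aromatic ring. In a functional assay on NCI-H630 cells (Homo sapiens) for cytotoxicity, read by sulforhodamine B assay, with a stated time of 5 days (on this read-out lower numbers stand for stronger inhibition and higher numbers for weaker inhibition), compound 1 gives 80000 nM. Compound 2 in this assay reaches only a limit, > 100000 nM, and not a number; this is the limit of > 100000 nM in this assay, at which 1 of the 3 values shown sits. The change from compound 1 to compound 2 is phenyl in place of benzyl on a saturated chain carbon, three bonds along the chain from a carbonyl carbon, and the step measured is an at least 1.2-fold higher number from compound 1 to compound 2 (0.09 log units; that floor lies within the scatter). Compound 3 in this assay gives 13000 nM; the difference between the cores of compound 1 and compound 3 is not broken down here. Compound 4 `O=C(CCCCCCCCc1ccccc1)CC(=O)N[C@H]1CCOC1=O` is not yet measured and differs from compound 3 by phenyl in place of benzyl on a saturated chain carbon, eight bonds along the chain from a carbonyl carbon. This is the same kind of change as from compound 1 to compound 2, but the place differs: three bonds along the chain from a carbonyl carbon there, eight bonds along the chain from a carbonyl carbon here. A small step, near the scatter and in the weaker direction, is expected for compound 4, estimated as a 1.5-fold higher number from compound 3 to compound 4 (0.19 log units; within the scatter), because compound 3 gave 13000 nM and the same kind of change gave an at least 1.2-fold higher number from compound 1 to compound 2 (0.09 log units; that floor lies within the scatter). Compound 4 is expected at 20000 nM, between 9000 nM and 50000 nM.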

Compound 4, half-maximal inhibitory concentration: 10000 nM
For compound 4 the middle estimate is 2.0-fold (0.30 log units) above the measured one; measured number inside the range.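

In this assay, phenyl in place of benzyl on a saturated chain carbon, eight bonds along the chain from a carbonyl carbon, gives a 1.3-fold lower number from compound 3 to compound 4 (0.11 log units; within the scatter). Compound 2 is held only at a limit, > 100000 nM, and not a number, so the earlier step on the core of compound 1 is known only as a floor. The result therefore neither confirms nor rules out that the change carries the same size from one core to the other: the same change on two cores in this assay, an at least 1.2-fold higher number (0.09 log units; that floor lies within the scatter) from compound 1 to compound 2 and a 1.3-fold lower number (0.11 log units; within the scatter) from compound 3 to compound 4; the limit leaves it open whether they differ

Still open, as far as these compounds go, is how a chain longer than that of compound 3 would read in this assay. Also open, from the compounds shown here alone, is the effect of an amine or a carboxylic acid in place of phenyl.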